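This account rests on a few compounds, and the source may have more. Where it says the series, first, only, none or still open, it means among the compounds named here.

Measured compounds:
compound 1 `CCCCCCOP(=O)(O)OC[C@H]1O[C@@H](n2ccc(N)nc2=O)[C@@H](O)[C@@H]1O`: 7.8 uM
compound 2 `CCCCCCCCCCCCCCCCOP(=O)(O)OC[C@H]1O[C@@H](n2ccc(N)nc2=O)[C@@H](O)[C@@H]1O`: 11 uM

In a functional assay on L1210 cells (Mus musculus) for inhibition (a lower number here means a stronger inhibitor, a higher number a weaker inhibitor), compound 1 gives 7.8 uM, the lowest of the two numbers; compound 2 gives 11 uM, and the step of a 1.4-fold higher number from compound 1 to compound 2 (0.15 log units; within the scatter) leaves the two within the scatter. Compound 3 `Nc1ccn([C@@H]2O[C@H](COP(=O)(O)OCC(O)CO)[C@@H](O)[C@@H]2O)c(=O)n1` differs from compound 1 by 1,2-dihydroxyethyl in place of pentyl on a saturated chain carbon bound to an oxygen on an unsaturated carbon. Within the data shown here, only one measured step exists, and it lengthens the chain without touching the part where compound 3 differs; it was within the scatter. Among the measured compounds shown here, no measured step covers an exchange of pentyl for 1,2-dihydroxyethyl on a saturated chain carbon bound to an oxygen on an unsaturated carbon, so the direction of the change is open. The expectation for compound 3 is therefore a step of a 1.5-fold higher number from compound 1 to compound 3 (0.19 log units; within the scatter), small in the middle but with wide uncertainty. Compound 3 is estimated at 12 uM in this assay, with a range from 3 uM to 50 uM.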

Compound 3, concentration for 50% inhibition: 0.65 uM
Compound 3: middle estimate off by 18-fold (1.27 log units), on the high side; the whole stated range lies above it.
By their numbers in this assay, from the lowest: compound 3; then compounds 1 and 2 (each within the scatter of the next).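

In this assay the exchange of pentyl for 1,2-dihydroxyethyl on a saturated chain carbon bound to an oxygen on an unsaturated carbon gives a 12-fold lower number from compound 1 to compound 3 (1.08 log units; beyond the scatter) and is a large step. Among these compounds, the earlier change, read as a 1.4-fold higher number from compound 1 to compound 2 (0.15 log units; within the scatter) and within the scatter, showed only that chain length made no clear difference between those two compounds; this position does respond when a dihydroxylated chain replaces an all-carbon one. No evidence on hand bears on what lies behind this step.

The compounds shown leave open whether both hydroxyl groups of 2,3-dihydroxypropyl are required, which a 2-hydroxyethyl or 2-methoxyethyl group at this place would test. As far as these compounds go, it also remains open whether other groups on this chain, such as an amine or a carboxylic acid, would move the number in the same direction.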